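A few compounds are considered here, and "the series" means these few. Any claim that something is new, unique, unknown or untested is made for them only; others in the source may bear on it.

Values in a functional assay for antagonist activity at transient receptor potential cation channel subfamily V member 1 (Homo sapiens), read by FLIPR; a lower number here means a stronger inhibitor, a higher number a weaker inhibitor:
compound 1 `Cc1cccnc1-c1ccc(C(=O)Nc2ccc(C(C)(C)C)cc2)cc1`: 11 nM
compound 2 `CCCOc1cccnc1-c1ccc(C(=O)Nc2ccc(C(C)(C)C)cc2)cc1`: 62 nM
compound 3 `CC(C)(C)c1ccc(NC(=O)c2ccc(-c3ncccc3NS(=O)(=O)c3ccccc3)cc2)cc1`: 91 nM

Compound 3 carries the highest number of the three. Its nearest neighbour is compound 2, with a 1.5-fold higher number from compound 2 to compound 3 (0.17 log units; within the scatter), so the two cannot be told apart. The furthest is compound 1, with an 8.3-fold higher number from compound 1 to compound 3 (0.92 log units; beyond the scatter).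

Compound 4 `CC(C)(C)c1ccc(NC(=O)c2ccc(-c3ncccc3C(=N)N)cc2)cc1` is not yet measured. Against compound 3 the change is a group of 3 heavy atoms (1 carbon, 2 nitrogen; no ring) in place of a group of 10 heavy atoms (6 carbon, 1 nitrogen, 2 oxygen, 1 sulfur; one six-membered aromatic ring of carbon only), on an aromatic carbon.

Within the data shown here, no measured step exchanges one such substituent for another of this kind. What the series does show is that both departures from the methyl of compound 1 raised the number: a 5.6-fold higher number from compound 1 to compound 2 (0.75 log units; beyond the scatter) and an 8.3-fold higher number from compound 1 to compound 3 (0.92 log units; beyond the scatter). Among the measured compounds shown here, the group entering in compound 4 is closer in size to the methyl of compound 1 than to the groups of compound 2 or compound 3, but it brings two hydrogen-bond donors where the methyl has none, and the series gives no step for that. The expectation is therefore a number somewhere between those of compound 1 and compound 3, with wide uncertainty. For compound 4 in this assay the estimate is 40 nM, within 8 nM to 250 nM, which as a step means a 2.3-fold lower number from compound 3 to compound 4 (0.36 log units; beyond the scatter), expected rather than known.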

Compound 4, half-maximal inhibitory concentration: > 4000 nM
Compound 4: only a limit was reported; the forecaster's own chance of this, stated with the estimate: 5%; middle value at least 100-fold (2.00 log units) away from the limit.
By their numbers in this assay, from the lowest: compound 1; then compounds 2 and 3 (each within the scatter of the next). At a limit, above all of these: compound 4.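

In this assay, compound 4 gives > 4000 nM, which is a limit of the assay and not a number: the limit of > 4000 nM in this assay, at which 1 of the 4 values shown sits.

Methyl, propoxy and (phenylsulfonyl)amino on this aromatic carbon, two atoms from the ring nitrogen, all gave measurable inhibition, but the group entering here breaks with them, with an at least 43-fold higher number from compound 3 to compound 4 (1.64 log units; beyond the scatter), an at least 64-fold higher number from compound 2 to compound 4 (1.80 log units; beyond the scatter) and an at least 360-fold higher number from compound 1 to compound 4 (2.56 log units; beyond the scatter). Heavy-atom count alone therefore does not order the changes at this position: the group of 3 heavy atoms in compound 4 is smaller than propoxy and (phenylsulfonyl)amino, yet it gives the largest loss of the series, so this carbon is sensitive to what is placed there and not only to how large it is.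

Which part of the entering group goes with the loss stays open, and a primary amide, a nitrile or an aminomethyl group on the same carbon would help to separate the possibilities. As far as these compounds go, it is also open whether a plain amine or a hydroxyl group at this place would stay with the first three compounds or fall with compound 4.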